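The source may report more compounds than this note shows. Statements on the series, on what has been measured and on what is new or still open speak of the compounds shown alone.

Measured compounds:
Compound 1, `C#CCSc1nc(N/N=C/c2cc(OC)c(OC)c(OC)c2)c2nnn(Cc3ccccc3)c2n1`, gives 4670 nM in a functional assay on MGC-803 cells (Homo sapiens) for antiproliferative activity, read by MTT assay, with a stated time of 72 h; on this read-out higher numbers stand for weaker inhibition and lower numbers for stronger inhibition.
Compound 2, `CCCSc1nc(N/N=C/c2cc(OC)c(OC)c(OC)c2)c2nnn(Cc3ccccc3)c2n1`, gives 9410 nM in this assay.

Compound 2 is not set apart from compound 1 on these numbers: a 2.0-fold higher number from compound 1 to compound 2 (0.30 log units; within the scatter). Compound 3, `COc1cc(/C=N/Nc2nc(SCc3ccccc3)nc3c2nnn3Cc2ccccc2)cc(OC)c1OC`, differs from compound 2 by phenyl in place of ethyl on a saturated chain carbon bound to a sulfur. For the measured compounds named here, the only measured step, from compound 1 to compound 2, concerns a different change at the same place and stays within the scatter, so nothing measured speaks to phenyl replacing ethyl. Compound 3 is therefore expected to show a step of a 1.3-fold lower number from compound 2 to compound 3 (0.13 log units; within the scatter), not beyond the scatter, and its estimated value is 7000 nM, within 2500 nM to 20000 nM.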

Compound 3, half-maximal inhibitory concentration: 1320 nM
Compound 3: the middle estimate sits 5.3-fold (0.72 log units) above what was measured; measured number outside the range, below it.
By their numbers in this assay, from the lowest: compound 3; then compounds 1 and 2 (each within the scatter of the next).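

In this assay, a saturated chain carbon bound to a sulfur now proves to be a place where a change can move the number beyond the scatter: phenyl in place of ethyl gives a 7.1-fold lower number from compound 2 to compound 3 (0.85 log units; beyond the scatter) and phenyl in place of ethynyl gives a 3.5-fold lower number from compound 1 to compound 3 (0.55 log units; beyond the scatter) in this series. For the compounds shown here, the only earlier step at this place stayed within the scatter. No measurement at hand explains these steps. Still open, going by these compounds, is whether a pyridine ring or a cyclohexyl ring in place of phenyl would give a similar number, and whether a substituent such as an amine on the phenyl would keep it.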